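The source may report more compounds than this note shows. Statements on the series, on what has been measured and on what is new or still open speak of the compounds shown alone.

Among the compounds with values here, in a functional assay on MCF7 cells (Homo sapiens) for cytotoxicity, read by CellTiter-Glo, with a stated time of 5 days (a lower number here means a stronger inhibitor, a higher number a weaker inhibitor), compound 2 `O=C(O)/C=C/c1ccc(/C(=C(\c2ccc(C(F)(F)F)cc2Cl)C2CCC2)c2ccc3[nH]nc(F)c3c2)cc1` gives 8.2 nM, the higher of the two numbers so far; compound 1 `CS(=O)(=O)c1ccc(/C(=C(\c2ccc(/C=C/C(=O)O)cc2)c2ccc3[nH]nc(F)c3c2)C2CCC2)c(Cl)c1` gives 2.3 nM, and the step of a 3.6-fold higher number from compound 1 to compound 2 (0.55 log units; beyond the scatter) is the only measured one. Compound 3 `O=C(O)/C=C/c1ccc(/C(=C(\c2ccccn2)C2CCC2)c2ccc3[nH]nc(F)c3c2)cc1` arises by pyridin-2-yl in place of 2-chloro-4-(trifluoromethyl)phenyl on a double-bonded chain carbon bound to a double-bonded chain carbon and a saturated ring carbon. Within the data shown here, the measured step exchanged a single substituent on the ring that now leaves entirely, so it bears only loosely on this change; no step in the set replaces the whole ring. A modest step is therefore expected, a 3.0-fold higher number from compound 2 to compound 3 (0.48 log units; beyond the scatter), most likely toward a higher number. Compound 3 is expected to give 25 nM, within 6 nM to 100 nM.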

Compound 3, half-maximal inhibitory concentration: 22 nM
Compound 3: the middle estimate sits 1.1-fold (0.06 log units) above what was measured, and the stated range covers the measured number.
By their numbers in this assay, from the lowest: compound 1; then compound 2; then compound 3.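

In this assay, the whole ring on this double-bonded chain carbon can be exchanged, not only one of its substituents: pyridin-2-yl gives a 2.7-fold higher number from compound 2 to compound 3 (0.43 log units; beyond the scatter) and a 9.6-fold higher number from compound 1 to compound 3 (0.98 log units; beyond the scatter). The two steps show that the methylsulfonyl-bearing ring is the better of the three rings here, and that the smaller pyridin-2-yl ring still gives a measurable number. No measured evidence bears on why the number rises.

From the compounds shown here alone, it remains open whether the rise follows the ring nitrogen or the loss of the ring substituents, as these change together. An unsubstituted phenyl ring would help separate them.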